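Shortening the butoxy chain on the shared core

A few compounds are considered here, and "the series" means these few. Any claim that something is new, unique, unknown or untested is made for them only; others in the source may bear on it.

Compound 1 `CCCCOc1cccc(C(=O)Nc2nn[nH]n2)n1` carries a butoxy group on its core and, in a functional assay on the whole organism for inhibition, with Rattus norvegicus as the target, at a dose of 3 mg/kg by the oral route (a higher number here means a stronger effect of the compound at the dose given, a lower number a weaker effect), compound 1 gives 18%, the lowest of the two values shown. Compound 2 `Cc1ccc(C)c(C(=O)Nc2nn[nH]n2)n1`, which carries two methyl groups on the same core, gives 65% in this assay, a number well beyond the scatter above the reading for compound 1. The two compounds differ in more than one place, so their gap is not counted as a single step. The unmeasured compound 3 `COc1cccc(C(=O)Nc2nn[nH]n2)n1` differs from compound 1 in one place: hydrogen in place of propyl on a saturated chain carbon bound to an oxygen on an aromatic ring. Going by the values given here, no single step of this kind has been measured, so the expected size rests on the two values alone. Since compound 2, the other small-substituted compound, gives 65%, a rise from compound 1 to compound 3 of about a number 17 percentage points higher from compound 1 to compound 3 (beyond the scatter) is expected. Compound 3 is therefore estimated at 35%, between 10% and 65%.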

Compound 3, a percentage reported as inhibition, in the whole organism at one dose (the size of the read-out at that dose, not a potency): 36%
Beside the measured number, compound 3's estimate is 1 percentage points below it, within the range that was stated.
By their numbers in this assay, from the lowest: compound 1; then compound 3; then compound 2.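

In this assay, going by these compounds alone, replacing butoxy with methoxy gives a number 18 percentage points higher from compound 1 to compound 3 (beyond the scatter), the first change at a single place on the shared core. This shows that the reading in the whole animal at this dose responds to the chain on this oxygen, and that losing the propyl part raises it, although one pair gives only the direction of this one change and not a trend along a series of chains. Nothing available explains the step.

An ethoxy or propoxy chain at the same place would show whether the reading moves gradually with each carbon lost or jumps at one particular length. On these data alone, it also remains open whether the oxygen itself matters, which an amine in place of that oxygen could test.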